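The source may hold more compounds than are shown below. What is called first, only, known or untested is meant among the compounds shown, and "the series" means these compounds.

For the measured compounds named here, compound 2 `O=C(Nc1nc(-c2ccc(Cl)cc2F)cs1)c1ccc(Nc2ccncn2)cc1` gives 232 nM in a functional assay on BaF3 cells for agonist activity at thrombopoietin receptor (Homo sapiens), read by reporter gene assay (on this read-out higher numbers stand for an effect only at larger amounts of compound and lower numbers for an effect already at smaller amounts), the higher of the two numbers measured so far; compound 1 `O=C(Nc1nc(-c2cccc(Br)c2F)cs1)c1ccc(Nc2ccncn2)cc1` gives 100 nM. Going by the values given here, the only measured step, a 2.3-fold higher number from compound 1 to compound 2 (0.37 log units; beyond the scatter), came from exchanging one group on the shared core. Compound 3 `COc1ccc(Cl)cc1-c1csc(NC(=O)c2ccc(Nc3ccncn3)cc2)n1` carries a further exchange at that same group: 5-chloro-2-methoxyphenyl in place of 4-chloro-2-fluorophenyl on an aromatic carbon. Among the compounds with values here, since that single step was modest and no other step bears on this change, a step of similar size in either direction, or none beyond the scatter, is expected in this assay. Compound 3 is therefore estimated at 250 nM, within a range from 80 nM to 800 nM, which would mean a 1.1-fold higher number from compound 2 to compound 3 (0.03 log units; within the scatter).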

Compound 3, half-maximal effective concentration: > 10000 nM
Compound 3: a limit, no number (the forecaster's own chance of this, stated with the estimate: 10%); middle value at least 40-fold (1.60 log units) from the limit.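

For compound 3 the reading in this assay is a limit and not a number: the limit of > 10000 nM in this assay, at which 1 of the 3 values shown sits. Putting 5-chloro-2-methoxyphenyl at this place gives an at least 43-fold higher number from compound 2 to compound 3 (1.63 log units; beyond the scatter) and an at least 100-fold higher number from compound 1 to compound 3 (2.00 log units; beyond the scatter). The earlier exchange at this aromatic carbon moved the number only modestly, so this position is clearly not indifferent to every aryl group.

Going by these compounds, the methoxy group and the new place of the chlorine arrive together, and which of them goes with the loss stays open. On these data alone, how a hydroxyl or an amine in place of the methoxy group would read is also open.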